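Removing a trifluoromethyl from the benzyl arm of compound 1

The source may report more compounds than this note shows. Statements on the series, on what has been measured and on what is new or still open speak of the compounds shown alone.

Compound 1 `Cc1cc(-c2ccccc2)n(/C(N)=N/S(=O)(=O)c2cc(C)c(Cl)cc2SCc2ccccc2C(F)(F)F)n1` is one of three compounds that share a core and differ in the aryl group carried on the saturated chain carbon bound to sulfur. In an ADME assay on microsomes from liver (Homo sapiens) for metabolic stability, read by LC-MS, using NADPH, tested at 5 uM (a lower number here means that the compound disappears faster, a higher number that the compound lasts longer), compound 1 gives 0.306 h, the highest of the three numbers. Compound 3 `Cc1cc(S(=O)(=O)/N=C(\N)n2nccc2-c2ccccc2)c(SCc2cccc3ccccc23)cc1Cl` gives 0.268 h, which lies within the scatter of compound 1, whereas compound 2 `Cc1cc(S(=O)(=O)/N=C(\N)n2nccc2-c2ccccc2)c(SCc2ccccc2C)cc1Cl` gives 0.0802 h, a gap beyond the scatter. Going by the values given here, the only single-point step among the measured compounds is a 3.3-fold higher number from compound 2 to compound 3 (0.52 log units; beyond the scatter), where a larger aryl group on that chain carbon went with a longer half-life.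

Compound 4 `Cc1cc(-c2ccccc2)n(/C(N)=N/S(=O)(=O)c2cc(C)c(Cl)cc2SCc2ccccc2)n1` is compound 1 with one change: hydrogen in place of trifluoromethyl on an aromatic carbon. This takes away bulk from the aryl group in the same region where the step from compound 2 to compound 3 mattered, and leaves compound 4 closer in size to compound 2 than to compound 1 or compound 3. Among the compounds with values here, no measured pair isolates this exact change, so the direction is inferred from that one step. The number for compound 4 in this assay is therefore expected to fall, with the estimated step being a 2.0-fold lower number from compound 1 to compound 4 (0.31 log units; beyond the scatter). Compound 4 is estimated at 0.15 h, within a range of 0.07 h to 0.32 h.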

Compound 4, half-life: 0.0938 h
Compound 4: the middle estimate sits 1.6-fold (0.20 log units) above what was measured; the range from low to high includes it.
By their numbers in this assay, from the lowest: compounds 2 and 4 (each within the scatter of the next); then compounds 3 and 1 (each within the scatter of the next).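

In this assay hydrogen in place of trifluoromethyl gives a 3.3-fold lower number from compound 1 to compound 4 (0.51 log units; beyond the scatter) with the rest of compound 1 unchanged, so a single group on this aromatic carbon, and not only an exchange of the whole aryl group, goes with a shift in half-life. The direction matches a 3.3-fold higher number from compound 2 to compound 3 (0.52 log units; beyond the scatter) in that the larger aryl group again carries the higher number, but this reading rests on just these two steps, which were taken on different compounds. Nothing measured here explains the shift in half-life.

As far as these compounds go, it remains open whether the higher number belongs to trifluoromethyl in particular, or whether a methyl, a chlorine, a methoxy or a nitrile on the same aromatic carbon would go with a similar half-life. Also open, from the compounds shown here alone, is how the number would respond to an amine or a carboxylic acid on this aryl group, or to a longer chain between the sulfur and the aryl group.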